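A few compounds are considered here, and "the series" means these few. Any claim that something is new, unique, unknown or untested is made for them only; others in the source may bear on it.

In an assay on U2OS cells for activation of nuclear factor erythroid 2-related factor 2 (Homo sapiens), read by chemiluminescence, with a stated time of 6 h (a lower number here means that less compound is needed, a higher number that more compound is needed for the effect), compound 2 `COc1cccc(S(=O)(=O)/C=C/c2ccccn2)c1` gives 2170 nM, the second highest of the three numbers at hand. Compound 1 `COc1ccccc1S(=O)(=O)/C=C/c1ccccn1` gives 9070 nM, and compound 3 `COc1cccc(S(=O)(=O)/C=C/c2cccc(Cl)n2)c1` gives 786 nM. Compound 4 `COc1cccc(S(=O)(=O)/C=C/c2ccc(Cl)cn2)c1` has not yet been measured in this assay. It differs from compound 2 in one respect: chloro in place of hydrogen on an aromatic carbon. Within the data shown here, the only measured step that bears on this change is a 2.8-fold lower number from compound 2 to compound 3 (0.44 log units; beyond the scatter), where the same group enters the shared core, though not on the same aromatic carbon of that ring. Among the measured compounds shown here, because that step a 2.8-fold lower number from compound 2 to compound 3 (0.44 log units; beyond the scatter) was modest and went toward a lower number, a step of roughly similar size and the same direction is expected here, with added uncertainty since no measured pair shows chloro at this carbon. Compound 4 is therefore estimated at 1300 nM, within a range from 500 nM to 3500 nM. That estimate corresponds to an expected step of a 1.7-fold lower number from compound 2 to compound 4 (0.22 log units; within the scatter).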

Compound 4, half-maximal effective concentration: 132 nM
Compound 4: middle estimate off by 9.8-fold (0.99 log units), on the high side; the whole stated range lies above it.
By their numbers in this assay, from the lowest: compound 4; then compound 3; then compound 2; then compound 1.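

In this assay, chloro in place of hydrogen on this aromatic carbon, two atoms from the ring nitrogen and para to a large group, gives a 16-fold lower number from compound 2 to compound 4 (1.22 log units; beyond the scatter) and so counts as a large step. The same group gave only a modest step elsewhere on this ring, a 2.8-fold lower number from compound 2 to compound 3 (0.44 log units; beyond the scatter), so the two steps show that the size of the change depends on which aromatic carbon carries the chloro, something a single chloro compound could not show. Nothing at hand accounts for the larger step at this carbon.

From the compounds shown here alone, it remains open whether an amine, a carboxylic acid or a bromo group on this same carbon would also lower the number. Going by these compounds, it is equally open whether chloro here would give a step of this size with the methoxy group placed as in compound 1.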